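Methyl addition in a pyridine-linked benzamide series

A few compounds are considered here, and "the series" means these few. Any claim that something is new, unique, unknown or untested is made for them only; others in the source may bear on it.

Measured in an assay on cells for inhibition of MAP kinase-interacting serine/threonine-protein kinase 1 (Homo sapiens), read by mobility shift assay, with stated times of 10 min and 60 min, in the presence of a further agent that is not named here; a lower number here means a stronger inhibitor, a higher number a weaker inhibitor:
compound 1 `Cc1[nH]ncc1-c1cncc(-c2ccc(C(N)=O)c(OC(C)C)c2)c1` gives 54 nM
compound 2 `Cc1n[nH]c(C)c1-c1cncc(-c2ccc(C(N)=O)c(OC(C)C)c2)c1` gives 33 nM
compound 3 `NC(=O)c1ccc(-c2cccnc2)cc1` gives 8800 nM

Compound 3 stands highest of the three; its values against compounds 1 and 2 show gaps beyond the scatter. The difference between the core of compound 3 and the core of compound 1 is not broken down here.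

Compound 4 `Cc1ncccc1-c1ccc(C(N)=O)cc1` is not yet measured. It differs from compound 3 by methyl in place of hydrogen on an aromatic carbon. The same kind of change is seen between compounds 1 and 2, where methyl in place of hydrogen on an aromatic carbon gave a 1.6-fold lower number from compound 1 to compound 2 (0.21 log units; within the scatter). The surroundings are not the same: in compound 4 the methyl enters on a six-membered aromatic ring with one nitrogen, next to the ring nitrogen and ortho to a group of 9 heavy atoms, whereas in compound 2 it enters on a five-membered aromatic ring with two nitrogens, next to the ring atom that bears a large group.

Given the small step from compound 1 to compound 2, a similarly small step is expected from compound 3 to compound 4, a 1.3-fold lower number from compound 3 to compound 4 (0.10 log units; within the scatter), with wider uncertainty from the different ring. Compound 4 is expected at 7000 nM, between 2500 nM and 20000 nM.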

Compound 4, half-maximal inhibitory concentration: 170000 nM
The estimate for compound 4 lay 24-fold (1.39 log units) below the measured number; the whole stated range lies below it.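

In this assay, methyl in place of hydrogen on an aromatic carbon gives a 19-fold higher number from compound 3 to compound 4 (1.29 log units; beyond the scatter), and this step does not match the earlier one: the same change on two cores in this assay, a 1.6-fold lower number (0.21 log units; within the scatter) from compound 1 to compound 2 and a 19-fold higher number (1.29 log units; beyond the scatter) from compound 3 to compound 4, 32-fold (1.50 log units) apart, beyond the scatter of two such steps

The result from one core therefore cannot be carried to the other as a general value for this change in this series. It does not show what separates the two steps, since the methyl enters a different ring in each pair and the cores also differ elsewhere, and these two pairs cannot tell those differences apart.

As far as these compounds go, it remains open whether the higher number for compound 4 is specific to methyl or would also arise with another group at that place, such as fluorine, methoxy or an amine. Also open, from the compounds shown here alone, is how a methyl would behave on the six-membered aromatic ring with one nitrogen in the core of compound 1, next to the ring nitrogen.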